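A few compounds are considered here, and "the series" means these few. Any claim that something is new, unique, unknown or untested is made for them only; others in the source may bear on it.

Compound 3, `CN(C)c1ccc([C@H]2CC(c3cc4ccccc4oc3=O)=NN2c2ccccc2)cc1`, stands lowest of the three compounds measured in a functional assay on the whole organism (strain albino) for inhibition, with Rattus norvegicus as the target, read by paw edema, with stated times of 1 h and 4 h, at a dose of 200 mg/kg by the oral route; a higher number here means more inhibition at the dose given (going by the name of the read-out), a lower number less inhibition: compound 3 gives 40.1%. Compound 1, `O=c1oc2ccccc2cc1C1=NN(c2ccccc2)[C@@H](c2ccc(Cl)cc2)C1`, gives 64.7%, and compound 2, `O=c1oc2ccccc2cc1C1=NN(c2ccccc2)[C@@H](c2ccc(Cl)cc2Cl)C1`, gives 67.5%. Both gaps to compound 3 lie beyond the scatter, as a number 24.6 percentage points lower from compound 1 to compound 3 (beyond the scatter) and a number 27.4 percentage points lower from compound 2 to compound 3 (beyond the scatter) show, whereas between the two chloro-bearing compounds there is no real difference, as a number 2.8 percentage points higher from compound 1 to compound 2 (within the scatter) shows.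

Compound 4, `O=c1oc2ccccc2cc1C1=NN(c2ccccc2)[C@@H](c2ccccc2[N+](=O)[O-])C1`, is the next compound to be measured. The change is 2-nitrophenyl in place of 4-(dimethylamino)phenyl on a saturated ring carbon. The two steps into compound 3 bear on it most: both show that the 4-(dimethylamino)phenyl group goes with clearly less inhibition than the chloro-bearing phenyl groups, so taking that group away in compound 4 is expected to bring the number back up by a modest amount. Within the data shown here, no measured compound carries a 2-nitrophenyl group, so the size of the expected step is uncertain. Compound 4 is estimated at 60%, in the range 45% to 72%. The expected step is a number 19.9 percentage points higher from compound 3 to compound 4 (beyond the scatter).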

Compound 4, a percentage reported as inhibition, in the whole organism at one dose (the size of the read-out at that dose, not a potency): 26.6%
Estimate against measurement, compound 4: 33.4 percentage points above, outside the stated range (below it).
By their numbers in this assay, from the lowest: compound 4; then compound 3; then compounds 1 and 2 (each within the scatter of the next).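

At this saturated ring carbon, losing the 4-(dimethylamino)phenyl group does not by itself restore inhibition in this assay: 2-nitrophenyl gives a number 13.5 percentage points lower from compound 3 to compound 4 (beyond the scatter). The gap to the chloro-bearing groups is wider still, at a number 38.1 percentage points lower from compound 1 to compound 4 (beyond the scatter) and a number 40.9 percentage points lower from compound 2 to compound 4 (beyond the scatter), so among these four compounds the two carrying chlorine read high and the two with a nitrogen-bearing group read low, and the choice of aryl group spans a larger range than the first three compounds revealed. Nothing measured here explains the low number for the nitro compound.

The compounds shown leave open whether a plain phenyl, a 4-nitrophenyl or a 4-methoxyphenyl group at this carbon would read nearer the chloro compounds or nearer the nitrogen-bearing ones. As far as these compounds go, each number also comes from a single dose, so how potency ranks across these compounds remains open.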